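From fluoro to imidazolyl: estimating compound 4

The source may hold more compounds than are shown below. What is called first, only, known or untested is meant among the compounds shown, and "the series" means these compounds.

- Compound 1 `CC(=O)c1c(C)[n+]([O-])c2cc(-n3ccnc3)c(F)cc2[n+]1[O-]`: 95700 nM
- Compound 2 `CCOC(=O)c1c(C)[n+]([O-])c2cc(F)c(F)cc2[n+]1[O-]`: 30600 nM
- Compound 3 `Cc1c(C(=O)OCc2ccccc2)[n+]([O-])c2cc(F)c(F)cc2[n+]1[O-]`: 55300 nM

In an ADME assay on Vero cells (Chlorocebus sabaeus) for cytotoxicity, read by MTT assay, with a stated time of 72 h (a lower number here means a stronger inhibitor, a higher number a weaker inhibitor), compound 2 gives 30600 nM and sits at the low end of these numbers, though compound 3 lies within the scatter of it and only compound 1 is higher beyond the scatter. Compound 4 `CCOC(=O)c1c(C)[n+]([O-])c2cc(-n3ccnc3)c(F)cc2[n+]1[O-]` has 1H-imidazol-1-yl in place of fluoro on an aromatic carbon. Among the measured compounds shown here, the one measured step, a 1.8-fold higher number from compound 2 to compound 3 (0.26 log units; within the scatter), lies within the scatter and concerns another place, so it says little here. Compound 1 also carries 1H-imidazol-1-yl and has the higher number, but it differs from compound 2 elsewhere too. In this assay a moderate rise is therefore expected, estimated as a 2.3-fold higher number from compound 2 to compound 4 (0.36 log units; beyond the scatter) (a rough expectation from few data). The estimate for compound 4 is 70000 nM (range 32000 nM to 150000 nM).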

Compound 4, half-maximal inhibitory concentration: 129000 nM
Compound 4: the middle estimate sits 1.8-fold (0.27 log units) below what was measured; low and high end bracket the measured number.
By their numbers in this assay, from the lowest: compounds 2, 3, 1 and 4 (each within the scatter of the next, the first and the last beyond it).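

In this assay the change from fluoro to 1H-imidazol-1-yl on this aromatic carbon, now seen alone, gives a 4.2-fold higher number from compound 2 to compound 4 (0.62 log units; beyond the scatter) and so clearly raises the number. With 1H-imidazol-1-yl in place, ethoxy instead of methyl on the carbonyl carbon gives a 1.3-fold higher number from compound 1 to compound 4 (0.13 log units; within the scatter) and stays within the scatter, so the two compounds cannot be ordered. Nothing measured here explains the rise. The compounds shown leave open whether another group on this carbon, such as an amine or a morpholine ring, would raise the number as far. They also leave open whether a chloro group would change it at all.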